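The source may hold more compounds than are shown below. What is called first, only, known or untested is meant among the compounds shown, and "the series" means these compounds.

Measured compounds:
compound 1 `CC/C(=C(/c1ccc(NC(=O)C(C)C)cc1)c1ccc(OC)cc1)c1ccccc1` – > 30000 nM
compound 2 `CC/C(=C(/c1ccc(NC(=O)C(C)C)cc1)c1ccc(OC)cc1)c1ccc(OCc2ccccc2)cc1` – 4200 nM

In a functional assay on HeLa cells (Homo sapiens) for inhibition, read by trypan blue exclusion, with a stated time of 72 h (a lower number here means a stronger inhibitor of growth, a higher number a weaker inhibitor of growth), compound 1 gives only a limit, > 30000 nM. Within the data shown here, compound 2 gives 4200 nM in this assay, the sole plain number among the two values shown. The step between them, an at least 7.1-fold lower number from compound 1 to compound 2 (0.85 log units; beyond the scatter), is therefore known only as a lower bound, resting on (the limit of > 30000 nM in this assay, at which 1 of the 2 values shown sits).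

Compound 3 `CC/C(=C(/c1ccc(NC(=O)C(C)C)cc1)c1ccc(OC)cc1)c1ccc(O)cc1` differs from compound 2 by hydrogen in place of benzyl on an oxygen on an aromatic ring. Among the measured compounds shown here, this is not the reverse of the measured step, since a hydroxy group remains where compound 1 carries hydrogen, so the only guide is that adding the benzyloxy group gave the step of an at least 7.1-fold lower number from compound 1 to compound 2 (0.85 log units; beyond the scatter). Taking the benzyl away again is expected to move the number back upward, by an amount estimated as a 2.9-fold higher number from compound 2 to compound 3 (0.46 log units; beyond the scatter). Compound 3 is therefore expected to give about 12000 nM in this assay, within a range of 3500 nM to 30000 nM.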

Compound 3, concentration for 50% growth inhibition: 5800 nM
Compound 3: middle estimate off by 2.1-fold (0.32 log units), on the high side; the range from low to high includes it.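

Hydrogen and benzyl on this oxygen cannot be told apart in this assay: the step is a 1.4-fold higher number from compound 2 to compound 3 (0.14 log units; within the scatter), so the benzyl ring of compound 2 is not needed for its growth inhibition. The hydroxy group alone accounts for the gain seen on the aromatic carbon, with the step of an at least 5.1-fold lower number from compound 1 to compound 3 (0.71 log units; beyond the scatter). Compound 1 gives only a limit, so the true size of this step remains unknown and it can be read only as a lower bound: the limit of > 30000 nM in this assay, at which 1 of the 3 values shown sits.

The compounds shown leave open whether the oxygen itself matters at this place, which an amine or a fluorine in the same spot could help to test. On these data alone, it is also open how a methyl or a longer chain on this oxygen would compare with hydrogen and benzyl.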